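Methoxy to hydroxy on the anisole-like ring of compound 2

A few compounds are considered here, and "the series" means these few. Any claim that something is new, unique, unknown or untested is made for them only; others in the source may bear on it.

Going by the values given here, compound 2 `COc1cc(C)cc(-c2nn(CC#N)cc2-c2ccnc(-c3ccc(N(C)C)cc3)c2)c1` is the stronger of the two compounds measured in a functional assay on SNB-75 cells (Homo sapiens) for inhibition, read by sulforhodamine B assay, with a stated time of 48 h; on this read-out lower numbers stand for stronger inhibition of growth and higher numbers for weaker inhibition of growth; compound 2 gives 286 nM, and the only other number, that of compound 1 `Cc1cc(O)cc(-c2nn(CC#N)cc2-c2ccnc(-c3ccc(Oc4ccccc4)cc3)c2)c1`, lies well beyond the usual scatter above it, compound 1 giving 3820 nM. Among the compounds with values here, compound 1 differs from compound 2 in more than one place, so the two values show only that gap and no single-change step. Compound 3 `Cc1cc(O)cc(-c2nn(CC#N)cc2-c2ccnc(-c3ccc(N(C)C)cc3)c2)c1` is the unmeasured compound; it differs from compound 2 by hydrogen in place of methyl on an oxygen on an aromatic ring. Within the data shown here, no measured pair shows this change alone. The step is small and removes only a single carbon, so a modest change in either direction, or none beyond the scatter, is expected, with compound 3 expected to stay much closer to compound 2 than to compound 1. The estimate for compound 3 in this assay is 420 nM, in a range from 150 nM to 1200 nM, meaning an expected step of a 1.5-fold higher number from compound 2 to compound 3 (0.17 log units; within the scatter).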

Compound 3, concentration for 50% growth inhibition: 1860 nM
Beside the measured number, compound 3's estimate is 4.4-fold (0.65 log units) below it; the measured number lies above the stated range.
By their numbers in this assay, from the lowest: compound 2; then compound 3; then compound 1.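

In this assay, the oxygen on the aromatic ring turns out to be a sensitive place: hydrogen in place of methyl, which is methoxy to hydroxy and takes away a single carbon, gives a 6.5-fold higher number from compound 2 to compound 3 (0.81 log units; beyond the scatter). With the hydroxy group held the same, dimethylamino in place of phenoxy on an aromatic carbon gives a 2.1-fold lower number from compound 1 to compound 3 (0.31 log units; beyond the scatter), so a second single change also moves the number beyond the scatter, and the two earlier compounds are now joined by single-change steps through compound 3. Nothing measured on these compounds explains either step.

The compounds shown leave open whether ethoxy or an amine at this place would hold the number of compound 2. They also leave open whether methoxy to hydroxy gives a step of the same size with phenoxy in place of dimethylamino.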